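Swapping a Furan for Phenyl on a Nucleoside Core

A few compounds are considered here, and "the series" means these few. Any claim that something is new, unique, unknown or untested is made for them only; others in the source may bear on it.

Compound 1 `Nc1nc(N)c2c(-c3ccoc3)cn([C@@H]3O[C@H](CO)[C@@H](O)[C@H]3O)c2n1` in an ADME assay on BJ cells (Homo sapiens), read by MTT assay, with a stated time of 72 h (a lower number here means a stronger inhibitor, a higher number a weaker inhibitor), gives > 100000 nM, which is a limit of the assay rather than a number.
Compound 2 `CN(C)c1ncnc2c1c(-c1cc3ccccc3o1)cn2[C@@H]1O[C@H](CO)[C@@H](O)[C@H]1O` gives > 100000 nM, again a limit.
Compound 3 `Cc1nc(N)c2c(-c3ccsc3)cn([C@@H]3O[C@H](CO)[C@@H](O)[C@H]3O)c2n1` gives > 100000 nM, also a limit.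

All three measured compounds sit at the limit of > 100000 nM in this assay, at which 3 of the 3 values shown sit, so compound 1 stands level with the others and no ranking among them can be read from these numbers. Within the data shown here, no step between two measured compounds is available to guide the next change. Compound 4 `Nc1nc(N)c2c(-c3ccccc3)cn([C@@H]3O[C@H](CO)[C@@H](O)[C@H]3O)c2n1` differs from compound 1 by phenyl in place of furan-3-yl on an aromatic carbon. With every measured value a limit, the step that the limit leaves unreadable from compound 1 to compound 4 is expected to be none beyond the scatter, most likely ending at the limit once more. Compound 4 is therefore estimated at about 150000 nM, within a range of 40000 nM to 500000 nM.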

Compound 4, half-maximal inhibitory concentration: > 100000 nM
Compound 4 ended at the assay's limit; the forecaster's own chance of this, stated with the estimate: 80%; the middle value is on the limit's open side.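

Among these compounds, compound 1 and compound 4 are both limits of the assay rather than numbers, so no step between them can be read: the limit of > 100000 nM in this assay, at which 4 of the 4 values shown sit. The compounds shown leave open whether furan-3-yl and phenyl differ at all in this assay.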